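The compounds below may be only part of what the source reports. "The series", "measured", "known", "first", "only" and "open" are said of these compounds alone.

Working notes on the series in a functional assay on the whole organism for antagonist activity, with Mus musculus as the target; a lower number here means that less compound is needed, a higher number that more compound is needed for the effect. Compound 2 `COc1cc(N)c(Cl)cc1NC(=O)C1CCN(CC2CC2)CC1` gives only a limit in this assay, > 10 mg/kg. Compound 1 `COc1cc(N)c(Cl)cc1NC(=O)C1CCN(C2CCCC2)CC1` likewise gives a limit, > 10 mg/kg. Compound 3 `CCCN1CCC(C(=O)Nc2cc(Cl)c(N)cc2OC)CC1` gives a limit as well, > 10 mg/kg. All three values thus sit together at the same limit (the limit of > 10 mg/kg in this assay, at which 3 of the 3 values shown sit), so none of the steps among them can be read: a step that the two limits leave unreadable from compound 1 to compound 2, a step that the two limits leave unreadable from compound 1 to compound 3 and a step that the two limits leave unreadable from compound 2 to compound 3 are all unreadable in size and in direction.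

Compound 4 `COc1cc(N)c(Cl)cc1NC(=O)C1CCN(Cc2cccc(C#N)c2)CC1` has not yet been measured in this assay. It differs from compound 2 by 3-cyanophenyl in place of cyclopropyl on a saturated chain carbon bound to an amine nitrogen in a ring. The measured steps touch the same place, exchanging one group on the saturated chain carbon bound to the amine nitrogen in the ring for another, but each of them runs between two limits and carries no size over. An aromatic ring bearing a nitrile enters where cyclopropyl leaves, a larger change than any of the measured ones, yet nothing measured shows whether that moves the dose. The step from compound 2 to compound 4 is therefore expected as a number no higher from compound 2 to compound 4 (the limit leaves the size open), with no direction supported. Compound 4 is expected near 10 mg/kg, between 3 mg/kg and 30 mg/kg, with a fair chance that this assay again reports only a limit.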

Compound 4, dose for half-maximal effect: > 4 mg/kg
Compound 4 ended at the assay's limit; the forecaster's own chance of this, stated with the estimate: 60%; the middle value does not contradict the limit.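

In this assay compound 4 gives > 4 mg/kg, which is a limit and not a number. The steps from compound 1, compound 2 and compound 3 to compound 4 all run between two limits, so none can be read in size or direction. The compounds shown leave open what dose any of them needs, and whether any group on the amine nitrogen in the ring changes that dose.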